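The compounds below may be only part of what the source reports. "The series", "measured", "known", "first", "only" and "open" are said of these compounds alone.

Compound 3 `COc1cc(-c2nnc(S)n2-c2ccc(N(C)C)cc2)cc(OC)c1OC` carries a free sulfanyl group on the shared core. In a functional assay on HCT-116 cells (Homo sapiens) for inhibition, read by MTT assay, with a stated time of 48 h (on this read-out lower numbers stand for stronger inhibition and higher numbers for weaker inhibition), compound 3 gives > 60000 nM, which is a limit of the assay rather than a number. Two related compounds show the same picture. Compound 1 `COc1ccc(-n2c(S)nnc2-c2cc(OC)c(OC)c(OC)c2)cc1` gives > 60000 nM in this assay, again a limit. Compound 2 `COc1ccc(C(=O)CSc2nnc(-c3cc(OC)c(OC)c(OC)c3)n2-c2ccc(OC)cc2)cc1`, in which ((4-methoxyphenyl)carbonyl)methyl replaces the hydrogen on the sulfur, gives > 60000 nM in this assay, also a limit. Because of the limit of > 60000 nM in this assay, at which 3 of the 3 values shown sit, the steps a step that the two limits leave unreadable from compound 1 to compound 2 and a step that the two limits leave unreadable from compound 1 to compound 3 give no readable size in either direction. Compound 4 `COc1cc(-c2nnc(SCC(=O)Nc3ccc(Cl)cc3)n2-c2ccc(N(C)C)cc2)cc(OC)c1OC` differs from compound 3 as follows: ((4-chlorophenyl)carbamoyl)methyl in place of hydrogen on a sulfur. The nearest measured step, from compound 1 to compound 2, also placed a group on that sulfur, yet its size stays hidden behind the two limits, so no direction can be drawn from it. Among the compounds with values here, compound 4 is expected to stay close to the limit, with an estimated step of an at least 1.3-fold lower number from compound 3 to compound 4 (0.12 log units; that floor lies within the scatter) for which no earlier step gives support. Compound 4 is therefore estimated at 45000 nM, with a range from 8000 nM to 150000 nM.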

Compound 4, half-maximal inhibitory concentration: 39300 nM
For compound 4 the middle estimate is 1.1-fold (0.06 log units) above the measured one, within the range that was stated.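

Within the data shown here, compound 4 is the first compound here to give a number rather than a limit in this assay, so a group on this sulfur now has a step with a readable floor, where the earlier steps could not be read at all. With ((4-chlorophenyl)carbamoyl)methyl in place of the hydrogen, the result is an at least 1.5-fold lower number from compound 3 to compound 4 (0.18 log units; that floor lies within the scatter). Only a floor can be given, and the full size of the step stays hidden, because one end of it rests on a limit: the limit of > 60000 nM in this assay, at which 3 of the 4 values shown sit.

As far as these compounds go, it remains open whether a plain methyl on the sulfur would give a readable value, or whether an amine in place of the chlorine would shift it. Also open, from the compounds shown here alone, is what ((4-chlorophenyl)carbamoyl)methyl would give on the core of compound 1, which carries methoxy instead of dimethylamino.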